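This account rests on a few compounds, and the source may have more. Where it says the series, first, only, none or still open, it means among the compounds named here.

Values in an assay on membranes from CHO cells for displacement of a labelled ligand from adenosine receptor A1 (Homo sapiens), read by scintillation counting, with a stated time of 60 min, tested at 1 uM; a lower number here means less inhibition, a higher number more inhibition at the concentration tested (going by the name of the read-out):
compound 1 `CCCOC(=O)C1=C(C)NC(=S)NC1c1ccoc1`: 4%
compound 2 `CC1=C(C(=O)OCc2ccccc2)C(c2ccoc2)NC(=S)N1`: 25%
compound 3 `CCCOC(=O)C1=C(C)NC(=S)NC1c1ccsc1`: 5%

Compound 3 stands second highest of the three numbers. Its nearest neighbour is compound 1, from which it is separated by a number 1 percentage points higher from compound 1 to compound 3 (within the scatter), a step that rests on the exchange of thiophen-3-yl for furan-3-yl on the saturated ring carbon. Among the compounds with values here, its furthest neighbour is compound 2, whose value stands clearly higher than that of compound 3; no single-point step links these two.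

Compound 4 `CC1=C(C(=O)OCc2ccccc2)C(c2ccsc2)NC(=S)N1` is not yet measured. It differs from compound 3 by phenyl in place of ethyl on a saturated chain carbon bound to an oxygen next to a carbonyl group. Within the data shown here, the one measured step that bears on this change is the same replacement made on the furan series, a number 21 percentage points higher from compound 1 to compound 2 (beyond the scatter), which lay beyond the scatter. Since compound 1 and compound 3 sit within the scatter of each other, the same change is expected to carry compound 3 upward by a comparable amount, giving an expected step of a number 21 percentage points higher from compound 3 to compound 4 (beyond the scatter).

For compound 4 in this assay the estimate is 26%, with a range from 10% to 42%.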

Compound 4, a percentage reported as inhibition, at one concentration (the size of the read-out at that concentration, not a potency): 3%
Compound 4: middle estimate off by 23 percentage points, on the high side, outside the stated range (below it).
By their numbers in this assay, from the lowest: compounds 4, 1 and 3 (each within the scatter of the next); then compound 2.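

In this assay, phenyl in place of ethyl on a saturated chain carbon bound to an oxygen next to a carbonyl group does not carry over between cores, since on the thiophen-3-yl core it gives a number 2 percentage points lower from compound 3 to compound 4 (within the scatter): the same change on two cores in this assay, a number 21 percentage points higher (beyond the scatter) from compound 1 to compound 2 and a number 2 percentage points lower (within the scatter) from compound 3 to compound 4, 23 percentage points apart, beyond the scatter of two such steps

Thiophen-3-yl in place of furan-3-yl on a saturated ring carbon also proves dependent on its partner group, giving a number 22 percentage points lower from compound 2 to compound 4 (beyond the scatter) once the phenyl change is present: the same change on two cores in this assay, a number 1 percentage points higher (within the scatter) from compound 1 to compound 3 and a number 22 percentage points lower (beyond the scatter) from compound 2 to compound 4, 23 percentage points apart, beyond the scatter of two such steps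

The two changes are thus not additive, and among these four compounds only compound 2, which pairs benzyl with furan-3-yl, stands apart from the rest.

On these data alone, it remains open whether a cyclohexyl in place of phenyl on that chain carbon, or a pyridine ring in place of furan-3-yl, would keep the rise seen with compound 2. These readings at a single concentration also leave the potency of compound 2 undefined.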